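The compounds below may be only part of what the source reports. "The series", "measured", "known", "first", "only" and "open" are said of these compounds alone.

Measured compounds:
Compound 1 `NC(=S)N/N=C1/C=C(Nc2cccc(Cl)c2)C(Nc2cccc(Cl)c2)=NC1=O` gives 3380 nM in a functional assay on HCT-116 cells (Homo sapiens) for antiproliferative activity, read by MTT assay, with a stated time of 72 h; a higher number here means a weaker inhibitor, a lower number a stronger inhibitor.
Compound 2 `NC(=S)N/N=C1/C=C(Nc2ccc(Cl)cc2)C(Nc2ccc(Cl)cc2)=NC1=O` gives 190 nM in this assay.
Compound 3 `N/C(=N\N=C1\C=C(Nc2cccc(Cl)c2)C(Nc2cccc(Cl)c2)=NC1=O)SCc1ccccc1` gives 11700 nM in this assay.

Compound 1 and compound 2 share the same atoms joined differently; how their two cores differ is not broken down here. Compound 3 is compound 1 with a group of 11 heavy atoms (8 carbon, 2 nitrogen, 1 sulfur; one six-membered aromatic ring of carbon only) in place of a group of 4 heavy atoms (1 carbon, 2 nitrogen, 1 sulfur; no ring), on a double-bonded nitrogen, and this change brought a 3.5-fold higher number from compound 1 to compound 3 (0.54 log units; beyond the scatter).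

Compound 4 `N/C(=N\N=C1\C=C(Nc2ccc(Cl)cc2)C(Nc2ccc(Cl)cc2)=NC1=O)SCc1ccccc1` is not yet measured. Within the data shown here, it comes from compound 2 by a group of 11 heavy atoms (8 carbon, 2 nitrogen, 1 sulfur; one six-membered aromatic ring of carbon only) in place of a group of 4 heavy atoms (1 carbon, 2 nitrogen, 1 sulfur; no ring), on a double-bonded nitrogen, the same change made at the same kind of place as the one from compound 1 to compound 3. The expectation for compound 4 rests on a single example, so it is uncertain; the two cores also differ, so the step could well differ in size.

Because compound 2 gives 190 nM and the step seen once was a 3.5-fold higher number from compound 1 to compound 3 (0.54 log units; beyond the scatter), the step from compound 2 to compound 4 is expected to be about a 3.7-fold higher number from compound 2 to compound 4 (0.57 log units; beyond the scatter) in this assay. Compound 4 is therefore estimated at 700 nM, expected to lie between 250 nM and 2500 nM.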

Compound 4, half-maximal inhibitory concentration: 9600 nM
For compound 4 the middle estimate is 14-fold (1.14 log units) below the measured one, outside the stated range (above it).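

Putting the larger group with its six-membered aromatic ring in place of the smaller group gave a 51-fold higher number from compound 2 to compound 4 (1.70 log units; beyond the scatter) in this assay. The number rose on both cores, so the direction of the change carried over, but its size did not: the same change on two cores in this assay, a 3.5-fold higher number (0.54 log units; beyond the scatter) from compound 1 to compound 3 and a 51-fold higher number (1.70 log units; beyond the scatter) from compound 2 to compound 4, 15-fold (1.16 log units) apart, beyond the scatter of two such steps

Among these compounds, with only two pairs, this shows that a step measured on one core can be a poor guide to its size on another, but it does not show why the two steps differ or how the change would behave on a third core.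

Among the compounds shown here, it remains open whether a small methyl group, or a chain ending in an amine, in place of the group that enters here would give a smaller rise in the number than the one seen for compound 4. Going by these compounds, it is also open whether the same wide gap between the two steps would appear on cores carrying fluorine instead of chlorine.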